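The source may hold more compounds than are shown below. What is called first, only, known or untested is meant among the compounds shown, and "the series" means these compounds.

Of the compounds shown here, three have so far been tested in a functional assay on HeLa cells (Homo sapiens) for antiproliferative activity, read by MTT assay, with a stated time of 72 h; on this read-out higher numbers stand for weaker inhibition and lower numbers for stronger inhibition. Compound 1 `O=c1cc(CSC(=S)N2CCCCC2)oc2cc(Cl)ccc12` gives only a limit there, > 25000 nM, not a number. Compound 2 `COc1ccc2oc(CSC(=S)N(C(C)C)C(C)C)cc(=O)c2c1` likewise stops at a limit, > 25000 nM. Compound 3 `CC(C)N(C(=S)SCc1cc(=O)c2ccc(Cl)cc2o1)C(C)C` also reaches a limit, > 30000 nM. Compound 3 and compound 1 differ in one place: piperidin-1-yl in place of diisopropylamino on a thiocarbonyl carbon. With both ends limits, the step that the two limits leave unreadable from compound 3 to compound 1 stays unreadable. The difference between the cores of compound 2 and compound 3 is not broken down here. Compound 4 `COc1ccc2oc(CSC(=S)N3CCCCC3)cc(=O)c2c1` carries the same change on the core of compound 2: piperidin-1-yl in place of diisopropylamino on a thiocarbonyl carbon. The step from compound 2 to compound 4 is expected to be small, a step that the limit leaves unreadable from compound 2 to compound 4, because compound 2 sits at the limit of > 25000 nM in this assay, at which 2 of the 3 values shown sit, while compound 3 sits at the limit of > 30000 nM in this assay, at which 1 of the 3 values shown sits, and the earlier step gave no readable size. Compound 4 is therefore expected to give about 40000 nM in this assay, most likely again as a limit.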

Compound 4, half-maximal inhibitory concentration: 11900 nM
Compound 4: middle estimate off by 3.4-fold (0.53 log units), on the high side; measured number below the stated range.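

In this assay, piperidin-1-yl in place of diisopropylamino on a thiocarbonyl carbon gives an at least 2.1-fold lower number from compound 2 to compound 4 (0.32 log units; beyond the scatter), so on the core of compound 2 the change lowers the number. On these data alone, compound 2 itself gives only a limit, > 25000 nM, so the true size of this step stays unknown. The same change from compound 3 to compound 1 joins two limits and cannot be read, so these compounds do not show whether the effect carries over from one core to the other.

As far as these compounds go, it remains open how a different amine on the thiocarbonyl carbon, such as morpholin-4-yl or dimethylamino, would compare with piperidin-1-yl. From the compounds shown here alone, it is also open whether compound 4 would keep its value with a core carrying another group, such as a fluorine atom, in place of the methoxy group.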